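This account rests on a few compounds, and the source may have more. Where it says the series, first, only, none or still open, it means among the compounds named here.

Two compounds from one series share a core that carries a terminal alkene, a secondary alcohol and an unsaturated lactone. Compound 1, `C=C1CC[C@@H]2[C@](C)(CO[Si](C)(C)C(C)(C)C)[C@H](O)CC[C@@]2(C)[C@@H]1C/C=C1/C(=O)OC[C@H]1OC(C)=O`, bears a silyl ether on the primary alcohol and an acetoxy group on the lactone ring; in a functional assay on Lu1 cells (Homo sapiens) for cytotoxicity, read by sulforhodamine B assay (on this read-out higher numbers stand for an effect only at larger amounts of compound and lower numbers for an effect already at smaller amounts), compound 1 gives 10.4 uM. Compound 2, `C=C1CC[C@@H]2[C@](C)(COC(C)=O)[C@H](O)CC[C@@]2(C)[C@@H]1C/C=C1/C(=O)OC[C@H]1O`, carries instead an acetyl on the primary alcohol and a free hydroxy on the lactone ring; in this assay compound 2 gives 14 uM. The two numbers sit within the usual scatter of one another, so nothing separates compound 2 from compound 1 on this read-out.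

Compound 3, `C=C1CC[C@@H]2[C@](C)(COC(C)=O)[C@H](O)CC[C@@]2(C)[C@@H]1C/C=C1/C(=O)OC[C@H]1OC(C)=O`, is reached from compound 2 by a single change: acetyl in place of hydrogen on an oxygen on a saturated carbon, that is hydroxy to acetoxy. Going by the values given here, no pair of measured compounds shows this exact change, and the two measured compounds differ at two places at once, so no step size can be drawn from them. Since both measured compounds, with and without an acetoxy on the lactone ring, fall in the same band, the expected step of a 1.2-fold lower number from compound 2 to compound 3 (0.07 log units; within the scatter) is none beyond the scatter. Compound 3 is therefore estimated at 12 uM in this assay, within a range of 5 uM to 30 uM.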

Compound 3, concentration for half-maximal effect: 19.8 uM
The estimate for compound 3 lay 1.7-fold (0.22 log units) below the measured number, within the range that was stated.
By their numbers in this assay, from the lowest: compounds 1, 2 and 3 (each within the scatter of the next).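

In this assay, acetyl in place of hydrogen on an oxygen on a saturated carbon now has a measured size: hydroxy to acetoxy gives a 1.4-fold higher number from compound 2 to compound 3 (0.15 log units; within the scatter) and so does not move the read-out beyond the scatter. Going by these compounds alone, the compounds also give a first reading for a second single change, acetyl in place of the silyl group on the other oxygen on a saturated carbon, and this gives a 1.9-fold higher number from compound 1 to compound 3 (0.28 log units; within the scatter) and also stays inside the scatter. Neither oxygen has yet shown a change that separates two compounds on this read-out, and nothing in the data explains why these steps are so small.

The compounds shown leave open whether an amine, a carboxylic acid or a longer chain on the oxygen of the hydroxy to acetoxy change would give a step beyond the scatter, since only hydrogen and acetyl have been compared there. They also leave open whether the same step would hold with the silyl group in place of the acetyl on the other oxygen, or whether a group such as benzoyl at either oxygen would separate itself from this band.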